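Swapping the Aryl Group on the Shared Core

This account rests on a few compounds, and the source may have more. Where it says the series, first, only, none or still open, it means among the compounds named here.

Measured compounds:
Compound 1, `C=CCn1c(=O)/c(=C\c2cccc(Cl)c2Cl)[nH]c(=O)/c1=C\c1ccccc1OC`: 2300 nM
Compound 2, `C=CCn1c(=O)/c(=C\c2ccccc2OC)[nH]c(=O)/c1=C\c1ccccc1OC`: 22400 nM
Compound 3, `C=CCn1c(=O)/c(=C\c2cccc(Br)c2)[nH]c(=O)/c1=C\c1ccccc1OC`: 5400 nM

In a functional assay on A549 cells (Homo sapiens) for cytotoxicity, read by CCK-8 assay, with a stated time of 72 h (on this read-out lower numbers stand for stronger inhibition and higher numbers for weaker inhibition), compound 3 stands second highest of the three numbers. Its nearest neighbour is compound 1, and the change from one to the other was a 2.3-fold higher number from compound 1 to compound 3 (0.37 log units; beyond the scatter). Its furthest neighbour is compound 2, and from that compound the change was a 4.1-fold lower number from compound 2 to compound 3 (0.62 log units; beyond the scatter). Compound 4, `C=CCn1c(=O)/c(=C\c2cc(F)ccc2C)[nH]c(=O)/c1=C\c1ccccc1OC`, has not yet been measured in this assay. It differs from compound 3 in one place: 5-fluoro-2-methylphenyl in place of 3-bromophenyl on a double-bonded chain carbon bound to an aromatic carbon.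

Both measured steps that touch compound 3 bear on this change, since each also swaps one substituted phenyl for another at the same place. The larger of them, from a methoxy-bearing ring to a halogen-bearing ring, was modest; the smaller, between two halogen-bearing rings, was smaller still. The entering group carries a halogen together with a methyl, so compound 4 is expected to stay close to compound 3, with a step of a 1.1-fold lower number from compound 3 to compound 4 (0.03 log units; within the scatter). The number for compound 4 in this assay is therefore estimated at 5000 nM, within a range from 1800 nM to 14000 nM.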

Compound 4, half-maximal inhibitory concentration: 4900 nM
Beside the measured number, compound 4's estimate is 1.0-fold (0.01 log units) above it; measured number inside the range.
By their numbers in this assay, from the lowest: compound 1; then compounds 4 and 3 (each within the scatter of the next); then compound 2.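

In this assay the step of a 1.1-fold lower number from compound 3 to compound 4 (0.04 log units; within the scatter) shows that, at this place, a ring carrying a fluorine and a methyl cannot be told apart from 3-bromophenyl. The gap to the 2-methoxyphenyl ring also extends to this new ring, with a 4.6-fold lower number from compound 2 to compound 4 (0.66 log units; beyond the scatter) as the step, and all three rings carrying a halogen now read lower than compound 2. The 2,3-dichlorophenyl ring keeps its advantage over the new ring too, with a 2.1-fold higher number from compound 1 to compound 4 (0.33 log units; beyond the scatter) as the step, and compound 1 remains the lowest of the four.

Going by these compounds, the fluorine and the methyl enter together, leaving the share of each unresolved, and how a ring carrying an amine or a carboxylic acid would read at this place remains open. Nothing available here accounts for these differences.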